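The compounds below may be only part of what the source reports. "The series", "measured", "known", "first", "only" and "open" are said of these compounds alone.

Two compounds share one core and differ only in where the trifluoromethyl group sits on the ring that carries the 4-methylpiperidin-1-yl group. Compound 1 `CC1CCN(c2nc(C(F)(F)F)ccc2CNC(=O)C(C)c2ccc3c(c2)CCC3)CC1` gives 57.4 nM in an assay on CHO-K1 cells for antagonist activity at transient receptor potential cation channel subfamily V member 1 (Homo sapiens), read by FLIPR; a lower number here means a stronger inhibitor, a higher number a weaker inhibitor. Compound 2 `CC1CCN(c2cc(C(F)(F)F)ccc2CNC(=O)C(C)c2ccc3c(c2)CCC3)CC1` gives 96.4 nM in this assay. The number for compound 2 is the higher of the two, but its gap to compound 1 lies within the usual scatter, so the two compounds cannot be told apart on these data. Compound 3 `CC1CCN(c2cc(C(C)(C)C)ccc2CNC(=O)C(C)c2ccc3c(c2)CCC3)CC1` has not yet been measured; it differs from compound 2 by tert-butyl in place of trifluoromethyl on an aromatic carbon. Among the compounds with values here, no measured pair shows how such an exchange moves the number, so the expectation rests on compound 2 alone, and the step of a 1.2-fold higher number from compound 2 to compound 3 (0.10 log units; within the scatter) is estimated to stay within the scatter, with no clear direction. Compound 3 is therefore expected to give about 120 nM in this assay, with a likely range from 40 nM to 400 nM.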

Compound 3, inhibition constant: 61.7 nM
Compound 3: the middle estimate sits 1.9-fold (0.29 log units) above what was measured; the range from low to high includes it.
By their numbers in this assay, from the lowest: compounds 1, 3 and 2 (each within the scatter of the next).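

In this assay the exchange of trifluoromethyl for tert-butyl on this aromatic carbon gives a 1.6-fold lower number from compound 2 to compound 3 (0.19 log units; within the scatter) and so leaves the two compounds indistinguishable. Within the data shown here, this is the first view of a change at this position: a group made of carbon only, with the same count of heavy atoms as the fluorine-bearing one, keeps the number in the same range, at least in this single pair. Nothing available explains this outcome.

Going by these compounds, it remains open whether a nitrile, an amine or a carboxylic acid at this position would also leave the number in this range. On these data alone, the exchange has also been read only on the core of compound 2, so whether tert-butyl gives the same result on the core of compound 1 is unknown.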